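A few compounds are considered here, and "the series" means these few. Any claim that something is new, unique, unknown or untested is made for them only; others in the source may bear on it.

Measured so far in a functional assay on HCT-15 cells (Homo sapiens) for cytotoxicity, read by CCK-8 assay and cell counting, with a stated time of 72 h; a lower number here means a stronger inhibitor, a higher number a weaker inhibitor:
- compound 1 `COc1ccc(-c2cc3ccccc3c(-c3cccc(OC)c3)n2)cc1` gives 1300 nM
- compound 2 `COc1ccc(-c2cc3ccccc3c(-c3ccc(O)cc3)n2)cc1` reaches only the assay limit, > 50000 nM
- compound 3 `COc1cc(OC)cc(-c2cc3ccccc3c(-c3cccc(OC)c3)n2)c1` gives 1170 nM

Compound 3 holds the lowest of the two numbers in this assay, but compound 1 sits within the scatter of it, so the two cannot be ranked. Among the measured compounds shown here, compound 2 is the one compound that gave no number, only a limit.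

Compound 4 `COc1cc(OC)cc(-c2cc3ccccc3c(-c3ccc(O)cc3)n2)c1` has not been measured. It differs from compound 3 in one place: 4-hydroxyphenyl in place of 3-methoxyphenyl on an aromatic carbon. The same exchange has been run once on this core, with the other aryl substituent differing: an at least 38-fold higher number from compound 1 to compound 2 (1.58 log units; beyond the scatter). That step is known only by its floor, because the limit of > 50000 nM in this assay, at which 1 of the 3 values shown sits, caps what the assay reports, so its true size may be larger still. For the measured compounds named here, only this single precedent bears on the step from compound 3, and no step tells whether the other substituent alters the outcome.

A large rise in this assay is therefore expected, most likely again into the limit. Compound 4 is expected to give 40000 nM, with a range from 8000 nM to 200000 nM. This amounts to an expected step of a 34-fold higher number from compound 3 to compound 4 (1.53 log units; beyond the scatter).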

Compound 4, half-maximal inhibitory concentration: 2780 nM
For compound 4 the middle estimate is 14-fold (1.16 log units) above the measured one; measured number below the stated range.
By their numbers in this assay, from the lowest: compounds 3 and 1 (each within the scatter of the next); then compound 4. At a limit, above all of these: compound 2.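

In this assay, putting 4-hydroxyphenyl in place of 3-methoxyphenyl at this position, next to the ring nitrogen, gives only a 2.4-fold higher number from compound 3 to compound 4 (0.38 log units; beyond the scatter), so this exchange does not by itself drive a compound to the limit. The outcome of the same change differs with the other aryl substituent on the shared core, and the position alone does not fix it: the same change on two cores in this assay, an at least 38-fold higher number (1.58 log units; beyond the scatter) from compound 1 to compound 2 and a 2.4-fold higher number (0.38 log units; beyond the scatter) from compound 3 to compound 4, at least 16-fold (1.20 log units) apart, beyond the scatter of two such steps Compound 2 gave a limit and not a number, so the gap between the two steps is itself a floor: the limit of > 50000 nM in this assay, at which 1 of the 4 values shown sits.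

The exchange alters both the place of the oxygen on the phenyl ring and the group that carries it, and the compounds shown cannot separate these two changes; a 3-hydroxyphenyl at this position would help to tell them apart. From the compounds shown here alone, it also remains open how an amine or a carboxylic acid on this phenyl ring would read in this assay, and whether the dependence on the other aryl substituent holds beyond these two pairs.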